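A few compounds are considered here, and "the series" means these few. Any claim that something is new, unique, unknown or untested is made for them only; others in the source may bear on it.

Compound 1 `Cc1cc(NC(C)C)nc(SCc2nc3ccccc3[nH]2)n1`: > 100000 nM
Compound 2 `Cc1cc(N2CCCCC2)nc(SCc2nc3ccccc3[nH]2)n1`: > 100000 nM
Compound 3 `Cc1cc(NNC(N)=S)nc(SCc2nc3ccccc3[nH]2)n1`: > 100000 nM

All three entries are for a functional assay on PC-3 cells (Homo sapiens) for cytotoxicity, read by MTT assay, with a stated time of 72 h (a higher number here means a weaker inhibitor, a lower number a stronger inhibitor), and each is a limit, not a number. Going by the values given here, the series so far shows (the limit of > 100000 nM in this assay, at which 3 of the 3 values shown sit). Compound 3 stands only at > 100000 nM, which is a limit.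

Compound 4 `Cc1cc(Nc2ccc(F)cc2)nc(SCc2nc3ccccc3[nH]2)n1` differs from compound 3 as follows: a group of 7 heavy atoms (6 carbon, 1 fluorine; one six-membered aromatic ring of carbon only) in place of a group of 4 heavy atoms (1 carbon, 2 nitrogen, 1 sulfur; no ring), on a nitrogen on an aromatic ring.

The measured steps bearing on this change are a step that the two limits leave unreadable from compound 1 to compound 3, a step that the two limits leave unreadable from compound 2 to compound 3 and a step that the two limits leave unreadable from compound 1 to compound 2. None gives a size, so no size carries over to the new step in this assay. The expected outcome is little or no readable change, with any change toward stronger inhibition. The expected step is an at least 1.4-fold lower number from compound 3 to compound 4 (0.15 log units; that floor lies within the scatter). For compound 4 the estimate is 70000 nM, with an expected range of 20000 nM to 100000 nM.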

Compound 4, half-maximal inhibitory concentration: 56200 nM
Compound 4: the middle estimate sits 1.2-fold (0.10 log units) above what was measured, within the range that was stated.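

In this assay, going by these compounds alone, 4-fluorophenyl on a nitrogen on an aromatic ring gives compound 4 the first value that is a number and not a limit, while the other compounds remain at a limit: the limit of > 100000 nM in this assay, at which 3 of the 4 values shown sit. The change reads as an at least 1.7-fold lower number from compound 3 to compound 4 (0.25 log units; that floor lies within the scatter), as an at least 1.7-fold lower number from compound 2 to compound 4 (0.25 log units; that floor lies within the scatter) and as an at least 1.7-fold lower number from compound 1 to compound 4 (0.25 log units; that floor lies within the scatter). Each of these floors lies within the scatter, so no clear gain in potency is established.

Whether the aromatic ring or the fluorine accounts for the reading remains open. Plain phenyl on the same nitrogen, or chlorine in place of the fluorine, would bear on that question.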